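Replacing the cyclopropyl acid with a gem-dimethyl acid

This account rests on a few compounds, and the source may have more. Where it says the series, first, only, none or still open, it means among the compounds named here.

Of the compounds shown here, three sharing one core have been tested in a functional assay on HFL1 cells for antagonist activity at sphingosine 1-phosphate receptor 2 (Homo sapiens), read by ELISA, with a stated time of 24 h; on this read-out lower numbers stand for stronger inhibition and higher numbers for weaker inhibition. Compound 1 `CC(C(=O)O)c1nn(Cc2cn3cc(OCC4CC4)c(Cl)cc3n2)c2ccccc2c1=O` gives 1.3 nM, compound 2 `O=C(O)Cc1nn(Cc2cn3cc(OCC4CC4)c(Cl)cc3n2)c2ccccc2c1=O` gives 4.8 nM, and compound 3 `O=C(O)C1(c2nn(Cc3cn4cc(OCC5CC5)c(Cl)cc4n3)c3ccccc3c2=O)CC1` gives 28 nM. Compound 3 therefore carries the highest number of the three, standing a 5.8-fold higher number from compound 2 to compound 3 (0.77 log units; beyond the scatter) and a 22-fold higher number from compound 1 to compound 3 (1.33 log units; beyond the scatter); among the measured compounds it is the weakest inhibitor.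

Compound 4 `CC(C)(C(=O)O)c1nn(Cc2cn3cc(OCC4CC4)c(Cl)cc3n2)c2ccccc2c1=O` is the next step: 1-carboxy-1-methylethyl in place of 1-carboxycyclopropyl on an aromatic carbon. The side group keeps the same count of heavy atoms, donors and acceptors, but the three-membered ring opens into two separate methyls. For the measured compounds named here, the steps that bear on this are the two that arrive at the 1-carboxycyclopropyl group, namely a 22-fold higher number from compound 1 to compound 3 (1.33 log units; beyond the scatter) and a 5.8-fold higher number from compound 2 to compound 3 (0.77 log units; beyond the scatter). Both show that the ring-closed acid sits well behind the open acids, the 1-carboxyethyl group of compound 1 most of all. Going by the values given here, no measured compound carries the 1-carboxy-1-methylethyl group itself, so the expectation rests on that comparison alone: a return toward the open acids is expected, a 3.1-fold lower number from compound 3 to compound 4 (0.49 log units; beyond the scatter), though it need not reach compound 1. Compound 4 is estimated at 9 nM, with a plausible range from 3 nM to 35 nM in this assay.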

Compound 4, half-maximal inhibitory concentration: 21 nM
Compound 4: the middle estimate sits 2.3-fold (0.37 log units) below what was measured; the measured number falls inside the stated range.
By their numbers in this assay, from the lowest: compound 1; then compound 2; then compounds 4 and 3 (each within the scatter of the next).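

Closing the two methyls into a three-membered ring makes no difference beyond the scatter at this position: a 1.3-fold lower number from compound 3 to compound 4 (0.12 log units; within the scatter) in this assay. The numbers of compound 3 and compound 4 are both high, one with the ring and one without it. What these two share is a saturated chain carbon with no hydrogen left on it. The full series on that carbon does not run in one direction: a single methyl gives the lowest number, while adding a second gives a 16-fold higher number from compound 1 to compound 4 (1.21 log units; beyond the scatter), and the two-methyl acid also falls behind the unbranched acid, with a 4.4-fold higher number from compound 2 to compound 4 (0.64 log units; beyond the scatter). The data shown offer no measured explanation for why one methyl and two methyls differ so sharply.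

From the compounds shown here alone, it remains open whether an ethyl group in place of the single methyl of the 1-carboxyethyl group would keep the low number, and whether a wider ring such as 1-carboxycyclobutyl would track compound 3. Going by these compounds, all four compounds carry a carboxylic acid, so the effect of a primary amide or a tetrazole at this position also stays unknown.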